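The compounds below may be only part of what the source reports. "The series", "measured", "known", "first", "only" and "open" are said of these compounds alone.

Measured so far:
compound 1, `COc1ccc2[nH]c([S+]([O-])Cc3nccc(N4CCCCC4)c3Cl)nc2c1`: 175 h
compound 2, `COc1ccc2[nH]c([S+]([O-])Cc3cc(N(C)C)c(Cl)cn3)nc2c1`: 96 h
compound 3, `COc1ccc2[nH]c([S+]([O-])Cc3cc(N(C)C)c(Br)cn3)nc2c1`: 101 h

Three compounds have been run through an ADME assay for pharmacokinetics, at pH 7.4; a higher number here means that the compound lasts longer, a lower number that the compound disappears faster. Compound 1 `COc1ccc2[nH]c([S+]([O-])Cc3nccc(N4CCCCC4)c3Cl)nc2c1` gives 175 h in this assay. Compound 2 `COc1ccc2[nH]c([S+]([O-])Cc3cc(N(C)C)c(Cl)cn3)nc2c1` gives 96 h, and compound 3 `COc1ccc2[nH]c([S+]([O-])Cc3cc(N(C)C)c(Br)cn3)nc2c1` gives 101 h. All three numbers lie within the scatter of one another, so none can be said to last longer than the others.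

Compound 2 and compound 3 differ in one place: bromo in place of chloro on an aromatic carbon. That change made a 1.1-fold higher number from compound 2 to compound 3 (0.02 log units; within the scatter).

Compound 4 `COc1ccc2[nH]c([S+]([O-])Cc3nccc(N4CCCCC4)c3Br)nc2c1` is not yet measured. It is related to compound 1 by the same kind of change: bromo in place of chloro on an aromatic carbon. The surroundings are not identical, since in compound 4 the new group sits ortho to a piperidin-1-yl group (6 heavy atoms) and ortho to a large group, whereas in compound 3 it sits ortho to a dimethylamino group (3 heavy atoms) and para to a large group. The difference between the two cores of compound 1 and compound 2 is not broken down here.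

Because a 1.1-fold higher number from compound 2 to compound 3 (0.02 log units; within the scatter) stayed within the scatter, the step from compound 1 to compound 4 in this assay is also expected to be small, about a 1.1-fold higher number from compound 1 to compound 4 (0.04 log units; within the scatter). Compound 4 is therefore estimated at 190 h, with a likely range from 110 h to 330 h.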

Compound 4, half-life: 300 h
Estimate against measurement, compound 4: 1.6-fold (0.20 log units) below; the measured number falls inside the stated range.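

In this assay, putting bromo in place of chloro on the core of compound 1 gives a 1.7-fold higher number from compound 1 to compound 4 (0.23 log units; within the scatter), so compound 4 cannot be said to last longer than compound 1. Set beside the same change on the core of compound 2, this step cannot be told apart from the earlier one: the same change on two cores in this assay, a 1.1-fold higher number (0.02 log units; within the scatter) from compound 2 to compound 3 and a 1.7-fold higher number (0.23 log units; within the scatter) from compound 1 to compound 4, 1.6-fold (0.21 log units) apart, within the scatter of two such steps. So on these two cores the change from chloro to bromo gives no step that stands clear of the scatter, but two pairs do not show that it would behave the same way on every core in this series, nor do they rule out a small real effect.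

The compounds shown leave open what other groups on that same aromatic carbon, such as a methyl group, a nitrile or a methoxy group, would do to the half-life. They also leave open whether the picture would hold if the piperidin-1-yl group gave way to a morpholine ring or a longer chain.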